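Swapping the Amine Substituent: What to Expect for Compound 4

A few compounds are considered here, and "the series" means these few. Any claim that something is new, unique, unknown or untested is made for them only; others in the source may bear on it.

Measured compounds:
compound 1 `CC(=O)Oc1ccc(C(=O)Nc2cc3ccc(OCC4CCCNC4)c(C)c3oc2=O)cc1CC=C(C)C`: 820 nM
compound 2 `CC(C)=CCc1cc(C(=O)Nc2cc3ccc(OCCCNCC(C)C)c(C)c3oc2=O)ccc1O`: 1320 nM
compound 3 `CC(C)=CCc1cc(C(=O)Nc2cc3ccc(OCCCNCCO)c(C)c3oc2=O)ccc1O`: 1560 nM

All three compounds share one core and differ only in the side chain on the amine nitrogen. In a functional assay on MCF7 cells (Homo sapiens) for antiproliferative activity (a lower number here means a stronger inhibitor, a higher number a weaker inhibitor), compound 2 gives 1320 nM, the second highest of the three numbers; compound 3 lies nearest to it and compound 1 furthest, yet both gaps fall within the usual scatter, so the three are indistinguishable on these data.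

Compound 4 `CC(C)=CCc1cc(C(=O)Nc2cc3ccc(OCCCN[C@H](C)c4ccccc4)c(C)c3oc2=O)ccc1O` is the unmeasured member. It differs from compound 2 in one place: 1-phenylethyl in place of isobutyl on an amine nitrogen.

Among the measured compounds shown here, only one measured step touches the same position, a 1.2-fold higher number from compound 2 to compound 3 (0.07 log units; within the scatter), and that exchange of one amine substituent for another left the number essentially unchanged. For the measured compounds named here, no measured step brings an aromatic ring or a defined stereocentre onto this nitrogen, so the present change reaches beyond what the data cover.

The step expected from this change, a 1.3-fold lower number from compound 2 to compound 4 (0.12 log units; within the scatter), is therefore small, with no clear direction. Compound 4 is estimated at 1000 nM in this assay, with a range from 350 nM to 2800 nM.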

Compound 4, half-maximal inhibitory concentration: 1450 nM
Beside the measured number, compound 4's estimate is 1.5-fold (0.16 log units) below it, and the stated range covers the measured number.
By their numbers in this assay, from the lowest: compounds 1, 2, 4 and 3 (each within the scatter of the next).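

In this assay, replacing isobutyl with 1-phenylethyl on the amine nitrogen gives a 1.1-fold higher number from compound 2 to compound 4 (0.04 log units; within the scatter) and replacing 2-hydroxyethyl with 1-phenylethyl gives a 1.1-fold lower number from compound 3 to compound 4 (0.03 log units; within the scatter). The earlier compounds had shown only an exchange between two open-chain groups at this nitrogen, whereas these steps show that bringing in an aromatic ring and a defined stereocentre also leaves the number within the scatter. Nothing available explains why these three groups read alike.

On these data alone, whether the mirror-image form of 1-phenylethyl, a plain benzyl group or a chain ending in a carboxylic acid would read the same on this nitrogen remains open. So does whether adding a second substituent, giving a tertiary amine, would move the number beyond the scatter.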